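The source may report more compounds than this note shows. Statements on the series, on what has been measured and on what is new or still open speak of the compounds shown alone.

In a functional assay on A2780 ADR cells (Homo sapiens) for cytotoxicity, read by MTT assay, with a stated time of 24 h (on this read-out lower numbers stand for stronger inhibition and higher numbers for weaker inhibition), compound 1 (`CCCCC[C@H](CCC[C@@H]1CC=CC(=O)O1)OC`) gives 20500 nM and compound 2 (`CCCCC[C@H](C[C@@H](O)C[C@@H]1CC=CC(=O)O1)OC`) gives 91500 nM as the higher of the two numbers. Hydroxy in place of hydrogen on a saturated chain carbon gave a 4.5-fold higher number from compound 1 to compound 2 (0.65 log units; beyond the scatter) as the only measured step. Compound 3 (`CCCCC[C@H](C[C@H](O)C[C@@H]1CC=CC(=O)O1)OC`) keeps that hydroxy, and the two compounds have the same atoms and bonds and differ only in configuration as drawn: 1 of 3 stereo elements differ; a stereocentre at a saturated chain carbon is drawn R in compound 2 and S in compound 3 separates it from compound 2. That measured step does not test a change of configuration, so in this assay only a small shift within the scatter is expected, with no firm direction. The expected change is a 1.3-fold lower number from compound 2 to compound 3 (0.12 log units; within the scatter) on this estimate. Compound 3 is expected at 70000 nM (range 25000 nM to 160000 nM).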

Compound 3, half-maximal inhibitory concentration: 30000 nM
Compound 3: the middle estimate sits 2.3-fold (0.37 log units) above what was measured; measured number inside the range.
By their numbers in this assay, from the lowest: compounds 1 and 3 (each within the scatter of the next); then compound 2.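

The step of a 3.1-fold lower number from compound 2 to compound 3 (0.48 log units; beyond the scatter) in this assay shows that the drawn configuration at this chain carbon counts, not only the presence of the hydroxy: the fact that compounds 2 and 3 differ only in the configuration as drawn. With the S configuration, hydroxy in place of hydrogen gives a 1.5-fold higher number from compound 1 to compound 3 (0.17 log units; within the scatter), so the larger rise seen with the R configuration does not hold for both forms of this hydroxy.

As far as these compounds go, whether an amine or a ketone at this carbon would give a similar result remains open. So does the effect of changing the configuration at the other two stereocentres.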